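This account rests on a few compounds, and the source may have more. Where it says the series, first, only, none or still open, it means among the compounds named here.

Compound 3 `CN1C(=O)C(c2ccccc2F)N(C)c2nc(Nc3ccc(S(N)(=O)=O)cc3)ncc21` stands lowest of the three numbers in an assay on Sf9 cells for inhibition of serine/threonine-protein kinase 4 (Homo sapiens), read by luminescence and ADP-Glo, with a stated time of 1 h, in the presence of a further agent that is not named here; on this read-out lower numbers stand for stronger inhibition and higher numbers for weaker inhibition: compound 3 gives 75 nM. Compound 1 `CN1C(=O)C(c2cccc(Cl)c2)N(C)c2nc(Nc3ccc(S(N)(=O)=O)cc3)ncc21` gives 989 nM and compound 2 `COc1cccc(C2C(=O)N(C)c3cnc(Nc4ccc(S(N)(=O)=O)cc4)nc3N2C)c1` gives 954 nM. The step from compound 1 to compound 2 is a 1.0-fold lower number from compound 1 to compound 2 (0.02 log units; within the scatter), whereas the steps to compound 3 are a 13-fold lower number from compound 1 to compound 3 (1.12 log units; beyond the scatter) and a 13-fold lower number from compound 2 to compound 3 (1.10 log units; beyond the scatter). Thus the aryl group on the saturated ring carbon is the one place so far where a single change moved the read-out beyond the scatter.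

Compound 4 `Cc1c(F)cccc1C1C(=O)N(C)c2cnc(Nc3ccc(S(N)(=O)=O)cc3)nc2N1C` is not yet measured. The change is 3-fluoro-2-methylphenyl in place of 2-fluorophenyl on a saturated ring carbon. For the measured compounds named here, no measured step tests a methyl added to this ring, so the steps that bear on it are only those from compound 1 and compound 2 to compound 3, both large, and both showing that the substitution pattern of this aryl ring can shift the number strongly. Since the new ring still carries a fluorine and differs by one added carbon, a step in either direction is possible, most likely small to modest. Compound 4 is expected to give about 150 nM, within 40 nM to 600 nM, which would mean an expected step of a 2.0-fold higher number from compound 3 to compound 4 (0.30 log units; within the scatter).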

Compound 4, half-maximal inhibitory concentration: 419 nM
Compound 4: the middle estimate sits 2.8-fold (0.45 log units) below what was measured; measured number inside the range.
By their numbers in this assay, from the lowest: compound 3; then compound 4; then compounds 2 and 1 (each within the scatter of the next).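

In this assay, 3-fluoro-2-methylphenyl on the saturated ring carbon gives a weaker result than 2-fluorophenyl, a 5.6-fold higher number from compound 3 to compound 4 (0.75 log units; beyond the scatter), so a fluorine on this aryl ring does not by itself preserve the number of compound 3. The same group still improves on the 3-methoxyphenyl and 3-chlorophenyl rings, a 2.3-fold lower number from compound 2 to compound 4 (0.36 log units; beyond the scatter) and a 2.4-fold lower number from compound 1 to compound 4 (0.37 log units; beyond the scatter), so this position now gives three separate levels rather than two. The data at hand offer no measured explanation for these differences.

The added methyl and the changed fluorine position arrive together in compound 4, so their separate contributions cannot be read from these compounds. On these data alone, it also remains open how this position responds to an aryl ring carrying an amine or a carboxylic acid, or to a saturated cyclohexyl group in place of the aryl ring.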